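The source may hold more compounds than are shown below. What is called first, only, known or untested is meant among the compounds shown, and "the series" means these compounds.

Measured compounds:
- compound 1, `O=C(Nc1ccc2nc(NC(=O)C3CCCCC3)sc2c1)c1c(Cl)cccc1Cl`: 0.015 ug/mL
- compound 2, `Cc1[nH][n+](C)c(C)c1C(=O)Nc1ccc2nc(NC(=O)C3CCCCC3)sc2c1`: 0.012 ug/mL
- compound 3, `Cc1cccc(C)c1NC(=O)Nc1ccc2nc(NC(=O)C3CCCCC3)sc2c1`: 0.56 ug/mL

In a functional assay on WI-38 VA13 cells (Homo sapiens) for cytotoxicity (on this read-out higher numbers stand for an effect only at larger amounts of compound and lower numbers for an effect already at smaller amounts), compound 1 gives the second highest of the three numbers; compound 2 lies close, a 1.3-fold lower number from compound 1 to compound 2 (0.10 log units; within the scatter), while compound 3 stands far off, a 37-fold higher number from compound 1 to compound 3 (1.57 log units; beyond the scatter).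

Compound 4, `CCCCCCNC(=O)Nc1nc2ccc(NC(=O)c3c(Cl)cccc3Cl)cc2s1`, has not yet been measured. It differs from compound 1 on the other side of the shared core: hexylamino in place of cyclohexyl on a carbonyl carbon. Among the compounds with values here, none of the measured steps touches this side of the molecule, so no direct precedent exists. Within the data shown here, the only related information is that turning the amide into a urea at the opposite end, in the step of a 37-fold higher number from compound 1 to compound 3 (1.57 log units; beyond the scatter), gave a much higher number, and the change to compound 4 likewise replaces an amide by a urea. Taken as a loose analogy, a step in this assay toward a higher number is expected for compound 4, but with wide uncertainty, since the analogy rests on a single step at a different position. The expected step is a 4.0-fold higher number from compound 1 to compound 4 (0.60 log units; beyond the scatter), and the estimate for compound 4 is 0.06 ug/mL, ranging from 0.012 ug/mL to 0.4 ug/mL.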

Compound 4, half-maximal effective concentration: 0.29 ug/mL
For compound 4 the middle estimate is 4.8-fold (0.68 log units) below the measured one, and the stated range covers the measured number.
By their numbers in this assay, from the lowest: compounds 2 and 1 (each within the scatter of the next); then compounds 4 and 3 (each within the scatter of the next).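

In this assay, replacing cyclohexyl with hexylamino on a carbonyl carbon gives a 19-fold higher number from compound 1 to compound 4 (1.29 log units; beyond the scatter). Within the data shown here, the earlier steps changed only the group on the other carbonyl carbon, so this is the first sign that the group at this position also matters, with a step well beyond the scatter. The change swaps a ring of carbon only for an open chain and adds a nitrogen with its hydrogen-bond donor, and nothing available explains the size of the step.

A single step cannot show whether losing the ring or gaining the nitrogen matters more. Cyclohexylamino would keep the ring alongside the new nitrogen, while hexyl would keep the open chain without it, so these two groups would separate the two changes.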